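A few compounds are considered here, and "the series" means these few. Any claim that something is new, unique, unknown or untested is made for them only; others in the source may bear on it.

Measured compounds:
compound 1, `CCN(Cc1cccs1)C(=O)COc1ccc(CO)cc1`: 21900 nM
compound 2, `Cc1ccc(OCC(=O)N(Cc2cccs2)c2ccn(C)n2)cc1`: 855 nM

Both compounds were tested in an assay on HEK293 cells for agonist activity at transient receptor potential cation channel subfamily M member 8 (Homo sapiens), read by fluorescence and calcium flux, with a stated time of 15 min; a lower number here means that less compound is needed, a higher number that more compound is needed for the effect. Compound 2 has the lower of the two numbers in this assay, giving 855 nM, while compound 1 in the same assay gives 21900 nM, a gap far beyond the usual scatter. The two structures differ in more than one place, so that gap cannot be tied to a single change.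

Compound 3, `Cc1ccc(OCC(=O)N(Cc2cccs2)C(C)(C)C)cc1`, has not yet been measured. It differs from compound 2 by one change: tert-butyl in place of 1-methyl-1H-pyrazol-3-yl on an amide-type nitrogen. Among the measured compounds shown here, no measured pair shows this kind of change, so the direction is uncertain. Compound 2 carries an aromatic group on the nitrogen where compound 3 carries a saturated one; some loss is expected, and the step of a 2.9-fold higher number from compound 2 to compound 3 (0.47 log units; beyond the scatter) is my estimate. For compound 3 an expected value of 2500 nM is estimated, with a range from 600 nM to 12000 nM.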

Compound 3, half-maximal effective concentration: 11000 nM
Compound 3: the middle estimate sits 4.4-fold (0.64 log units) below what was measured; low and high end bracket the measured number.
By their numbers in this assay, from the lowest: compound 2; then compounds 3 and 1 (each within the scatter of the next).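

Among the compounds shown here, this pair is the first in which only one place changes, so the group on the amide-type nitrogen can now be judged on its own: tert-butyl in place of 1-methyl-1H-pyrazol-3-yl gives a 13-fold higher number from compound 2 to compound 3 (1.11 log units; beyond the scatter) in this assay. This position therefore matters for the read-out, and of these two groups, 1-methyl-1H-pyrazol-3-yl goes with the lower number. No measurement at hand tells which part of this swap accounts for the step, since the ring, its two nitrogens and its methyl all leave together. Still open, as far as these compounds go, is whether any aromatic ring on this nitrogen would serve as well, or only this one. A plain phenyl ring and a saturated cyclohexyl ring in the same place would help to separate these possibilities.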